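Chloro to hydrogen on the fused core of compound 2

The compounds below may be only part of what the source reports. "The series", "measured", "known", "first", "only" and "open" are said of these compounds alone.

Two compounds have numbers in an ADME assay on MCF-10A cells (Homo sapiens) for cytotoxicity, read by sulforhodamine B assay, with a stated time of 48 h; on this read-out higher numbers stand for weaker inhibition of growth and lower numbers for stronger inhibition of growth. Compound 1 `O=C1C(=O)N(CN2CCN(c3ccnc4cc(Cl)ccc34)CC2)c2cccc(Br)c21` gives 65600 nM in this assay. Compound 2 `NC(=S)N/N=C1/C(=O)N(CN2CCN(c3ccnc4cc(Cl)ccc34)CC2)c2cccc(Cl)c21` gives 19800 nM in this assay, the lower of the two numbers, and the gap to compound 1 lies beyond the scatter of repeated measurements. Going by the values given here, the two differ in more than one place, so no single step links them. Compound 3 `NC(=S)N/N=C1/C(=O)N(CN2CCN(c3ccnc4cc(Cl)ccc34)CC2)c2ccccc21` is not yet measured. It differs from compound 2 by hydrogen in place of chloro on an aromatic carbon. Among the compounds with values here, no pair shows what removing this chloro does, so the step is expected to stay within the usual scatter, with no clear direction, and a slightly higher number is the more likely side. The step from compound 2 to compound 3 is expected to be a 1.3-fold higher number from compound 2 to compound 3 (0.10 log units; within the scatter). For compound 3 the estimate in this assay is 25000 nM, with a range from 10000 nM to 60000 nM.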

Compound 3, concentration for 50% growth inhibition: 27700 nM
Compound 3: middle estimate off by 1.1-fold (0.04 log units), on the low side, within the range that was stated.
By their numbers in this assay, from the lowest: compounds 2 and 3 (each within the scatter of the next); then compound 1.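

In this assay the series gains its first single-place step, hydrogen in place of chloro on an aromatic carbon of the fused system (a 1.4-fold higher number from compound 2 to compound 3 (0.15 log units; within the scatter)). At this position, on this read-out, the chloro can therefore be removed without a shift that stands out from repeated measurements, so compound 2 and compound 3 cannot be ordered. No supporting data bear on why this step is so small.

Going by these compounds, it remains open whether an amine or a methoxy group on this same aromatic carbon would move the number beyond the scatter, and in which direction. Going by these compounds alone, compound 1 stays apart from this comparison, since no single step links it to compound 2 or compound 3.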